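The source may report more compounds than this note shows. Statements on the series, on what has been measured and on what is new or still open speak of the compounds shown alone.

Compound 1 `O=C(O)c1ccc(-c2cnc(C(=O)CCCCCCc3ccccc3)o2)cc1` gives 60 nM in an assay (Rattus norvegicus) for inhibition of Fatty-acid amide hydrolase 1 (Homo sapiens); a higher number here means a weaker inhibitor, a lower number a stronger inhibitor. Compound 2 `N#Cc1ccc(-c2cnc(C(=O)CCCCCCc3ccccc3)o2)cc1` gives 40 nM in this assay, and a 1.5-fold lower number from compound 1 to compound 2 (0.18 log units; within the scatter) is the step that separates the two. Compound 3 `O=C(CCCCCCc1ccccc1)c1ncc(-c2ncccc2C(=O)O)o1` is known in this assay only as a limit, > 50 nM, which is where one of the three values shown sits (the limit of > 50 nM in this assay, at which 1 of the 3 values shown sits). Set against compound 1, the change from compound 1 to compound 3 is a step that the limit leaves unreadable from compound 1 to compound 3; set against compound 2, the step from compound 2 to compound 3 is an at least 1.2-fold higher number from compound 2 to compound 3 (0.09 log units; that floor lies within the scatter). Compound 4 `O=C(CCCCCCc1ccccc1)c1ncc(I)o1` has not yet been measured; it differs from compound 3 in one place (iodo in place of 3-carboxypyridin-2-yl on an aromatic carbon). Within the data shown here, no measured step removes an aromatic group from that position, so the two steps that reach compound 3 say little about the direction here, and the floor of the step from compound 2 tells nothing of the size. The expected step from compound 3 to compound 4 is a step that the limit leaves unreadable from compound 3 to compound 4, and compound 4 is estimated to give about 200 nM in this assay, in a range from 40 nM to 2000 nM.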

Compound 4, inhibition constant: 3 nM
Estimate against measurement, compound 4: 67-fold (1.82 log units) above, outside the stated range (below it).
By their numbers in this assay, from the lowest: compound 4; then compounds 2 and 1 (each within the scatter of the next).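

The earlier steps shown here only swapped one aromatic substituent for another, and they either stayed within the scatter or could not be read, whereas here a single iodo on the carbon next to the ring oxygen, with no aromatic ring at that place, gives large steps: a 13-fold lower number from compound 2 to compound 4 (1.12 log units; beyond the scatter) and a 20-fold lower number from compound 1 to compound 4 (1.30 log units; beyond the scatter). Against the 3-carboxypyridin-2-yl group, the change gives an at least 16-fold lower number from compound 3 to compound 4 (1.22 log units; beyond the scatter), and that size is only a floor. Compound 3 is known only as a limit: the limit of > 50 nM in this assay, at which 1 of the 4 values shown sits.

So an aromatic ring at this position is not needed for a low number in this assay. The compounds shown leave open whether the gain belongs to iodine itself or to the loss of the ring, as they include no hydrogen, chloro, bromo or unsubstituted phenyl at this position.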